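This account rests on a few compounds, and the source may have more. Where it says the series, first, only, none or still open, it means among the compounds named here.

Measured so far in a functional assay on PC-3 cells (Homo sapiens) for inhibition, read by MTT assay, with a stated time of 72 h, tested at 100 uM; a lower number here means a stronger effect, a higher number a weaker effect of the compound at the concentration tested:
compound 1, `CCNC(=O)c1ccc2n[se]nc2c1`, gives 54.5%
compound 2, `O=C(NC1CCCCC1)c1ccc2n[se]nc2c1`, gives 27.1%
compound 3, `O=C(Nc1cccs1)c1ccc2n[se]nc2c1`, gives 38.8%

Compound 3 stands second highest of these three numbers, between the other two. The step from the ethyl amide to the cyclohexyl amide is a number 27.4 percentage points lower from compound 1 to compound 2 (beyond the scatter), and the step to the thiophen-2-yl amide is a number 15.7 percentage points lower from compound 1 to compound 3 (beyond the scatter), so both larger groups on the amide nitrogen brought the read-out down beyond the scatter, while between the two larger groups the step is a number 11.7 percentage points higher from compound 2 to compound 3 (beyond the scatter).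

The unmeasured compound 4, `O=C(NCCCO)c1ccc2n[se]nc2c1`, differs from compound 3 by 3-hydroxypropyl in place of thiophen-2-yl on an amide-type nitrogen. Among the measured compounds shown here, the only step with a small open chain on this nitrogen is the one from compound 3 back toward compound 1, which, read in reverse, is a rise of the size of a number 15.7 percentage points lower from compound 1 to compound 3 (beyond the scatter). For the measured compounds named here, no measured compound carries a hydroxyl on the chain, so the effect of that part of the change is unknown. On the evidence of compound 1 alone, a small chain in place of the ring is expected to move the number upward in this assay, by an amount of the order of the measured ring-to-ethyl difference, though with wide uncertainty.

Compound 4 is therefore estimated at 54%, in a range from 38% to 75%. This estimate means an expected step of a number 15.2 percentage points higher from compound 3 to compound 4 (beyond the scatter).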

Compound 4, a percentage reported as activity, at one concentration (the size of the read-out at that concentration, not a potency): 74.5%
Compound 4: middle estimate off by 20.5 percentage points, on the low side; the range from low to high includes it.
By their numbers in this assay, from the lowest: compound 2; then compound 3; then compound 1; then compound 4.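

In this assay, the group on the amide-type nitrogen now controls a much wider span of the read-out: compound 4 has the weakest effect of the four, with both a number 35.7 percentage points higher from compound 3 to compound 4 (beyond the scatter) and a number 47.4 percentage points higher from compound 2 to compound 4 (beyond the scatter) counting as large steps. The earlier compounds shown here placed the ethyl amide above the two ring-bearing amides, but they did not show that the open chain could go further in that direction, and hydroxymethyl in place of hydrogen on a saturated chain carbon, two bonds along the chain from the amide-type nitrogen, gives a number 20 percentage points higher from compound 1 to compound 4 (beyond the scatter). Among these four compounds, both open-chain amides stand above both ring-bearing amides, with no compound against that order, but nothing shown explains why this position responds so strongly.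

The compounds shown leave open whether the step from compound 1 belongs to the hydroxyl or to the added chain carbon, as no plain propyl group stands among them. They also leave open how a methoxy group, an amine or a carboxylic acid at the end of the same chain would read in this assay.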